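Methyl addition on a second ring: stability notes

The compounds below may be only part of what the source reports. "The series", "measured", "known", "first", "only" and "open" are said of these compounds alone.

Compound 1 `COC(=O)Nc1cc(-c2ccc(OC[C@@](C)(N)CC(C)C)c(C)c2)ccn1` and compound 2 `COC(=O)Nc1cc(-c2ccc(OC[C@@](C)(N)CC(C)C)nc2)ccn1` carry the same side chain and carbamate; the difference between the two cores is not broken down here. In an ADME assay on microsomes from liver (Mus musculus) for metabolic stability, read by LC-MS, using NADPH, with a stated time of 10 min, tested at 0.5 uM (on this read-out lower numbers stand for a less stable compound and higher numbers for a more stable compound), compound 1 gives 75%, and compound 2 gives 79%. Compound 3 `COC(=O)Nc1cc(-c2ccc(OC[C@@](C)(N)CC(C)C)c(C)c2C)ccn1` carries methyl in place of hydrogen on an aromatic carbon relative to compound 1, a step of a number 5 percentage points lower from compound 1 to compound 3 (within the scatter); compound 3 gives 70%. Compound 4 `COC(=O)Nc1cc(-c2cnc(OC[C@@](C)(N)CC(C)C)cc2C)ccn1`, not yet measured, carries methyl in place of hydrogen on an aromatic carbon relative to compound 2. This is the same kind of change, not the same: in compound 3 the methyl sits on a six-membered aromatic ring of carbon only, ortho to a methyl group, whereas in compound 4 it sits on a six-membered aromatic ring with one nitrogen, opposite the ring nitrogen. Because a number 5 percentage points lower from compound 1 to compound 3 (within the scatter) stayed within the scatter, a step of a number 5 percentage points lower from compound 2 to compound 4 (within the scatter) is expected. Compound 4 is estimated at 74%, expected to fall between 60% and 86%.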

Compound 4, percent of the compound remaining: 69%
Compound 4: the middle estimate sits 5 percentage points above what was measured, and the stated range covers the measured number.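

In this assay the methyl addition on the second core reads a number 10 percentage points lower from compound 2 to compound 4 (within the scatter), and the two cores do not separate: the same change on two cores in this assay, a number 5 percentage points lower (within the scatter) from compound 1 to compound 3 and a number 10 percentage points lower (within the scatter) from compound 2 to compound 4, 5 percentage points apart, within the scatter of two such steps

On these two cores, then, methyl in place of hydrogen on an aromatic carbon carries over with no difference that can be told from scatter. This rests on a single pair of steps, each within the scatter and with the methyl on differently built rings, so it does not show that the change is without effect or that it would carry to a further core.

Open, as far as these compounds go, is whether ethyl or chlorine in place of this methyl would read alike on both cores. Also open, from the compounds shown here alone, is whether the step holds with a longer chain in place of the (2-amino-2,4-dimethylpentyl)oxy group.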